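A few compounds are considered here, and "the series" means these few. Any claim that something is new, unique, unknown or untested is made for them only; others in the source may bear on it.

Compound 1 `CCCS(=O)(=O)Nc1ccc(F)c(C(=O)c2n[nH]c3ncc(-c4cccc(F)c4)cc23)c1F` gives 8.2% in an assay for binding affinity to dual specificity mitogen-activated protein kinase kinase 4 (Homo sapiens), read by KINOMEscan, tested at 100 nM; on this read-out higher numbers stand for a weaker effect at the one concentration tested and lower numbers for a stronger effect. Compound 2 `CCCS(=O)(=O)Nc1ccc(F)c(C(=O)c2n[nH]c3ncc(-c4ccc(S(=O)(=O)NCC)cc4)cc23)c1F` gives 3% in this assay.

Compound 2 holds the lowest of the two numbers, with compound 1 nearest to it; a number 5.2 percentage points lower from compound 1 to compound 2 (within the scatter). Compound 3 `CCCS(=O)(=O)Nc1ccc(F)c(C(=O)c2n[nH]c3ncc(-c4ccc(-c5nnn[nH]5)cc4)cc23)c1F` differs from compound 2 by 1H-tetrazol-5-yl in place of ethylsulfamoyl on an aromatic carbon. Within the data shown here, no measured step touches this part of the structure: the only step known, a number 5.2 percentage points lower from compound 1 to compound 2 (within the scatter), altered a different group and stayed within the scatter. The number for compound 3 is therefore expected to stay close, with a number 3 percentage points higher from compound 2 to compound 3 (within the scatter). Compound 3 is estimated at 6%, within a range from 1% to 20%.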

Compound 3, a percentage reported as activity, at one concentration (the size of the read-out at that concentration, not a potency): 0.15%
Compound 3: middle estimate off by 5.9 percentage points, on the high side; measured number below the stated range.
By their numbers in this assay, from the lowest: compounds 3, 2 and 1 (each within the scatter of the next).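

Putting a 1H-tetrazol-5-yl ring in place of the open ethylsulfamoyl group gives a small step in this assay (a number 2.9 percentage points lower from compound 2 to compound 3 (within the scatter)). Set against the 3-fluorophenyl of compound 1, the 4-(1H-tetrazol-5-yl)phenyl group also stays within the scatter (a number 8.1 percentage points lower from compound 1 to compound 3 (within the scatter)). This position, para to a large group, therefore carries a third, differently built substituent with all three numbers within the scatter of the next.

As far as these compounds go, whether a carboxylic acid or an amine in the same place would keep the number this small remains open. Nothing available here explains the tetrazole result.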